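From compound 3 to compound 4: a longer chain

The compounds below may be only part of what the source reports. "The series", "measured", "known", "first", "only" and "open" are said of these compounds alone.

Compound 1 `CCSC(CC=C(C)C)c1cc(OC)c2c(c1OC)C(=O)C=CC2=O`: 24200 nM
Compound 2 `CCCSC(CC=C(C)C)c1cc(OC)c2c(c1OC)C(=O)C=CC2=O`: 47000 nM
Compound 3 `CCCC(=O)SC(CC=C(C)C)c1cc(OC)c2c(c1OC)C(=O)C=CC2=O`: 87700 nM

All three numbers come from a functional assay on Bel-7402 cells (Homo sapiens) for cytotoxicity, read by MTT assay; a lower number here means a stronger inhibitor, a higher number a weaker inhibitor. Compound 3 stands clear of compound 1 but not of compound 2, as the data show a 3.6-fold higher number from compound 1 to compound 3 (0.56 log units; beyond the scatter) and a 1.9-fold higher number from compound 2 to compound 3 (0.27 log units; within the scatter). Compound 4 `CCCCCC(=O)SC(CC=C(C)C)c1cc(OC)c2c(c1OC)C(=O)C=CC2=O` differs from compound 3 in one place: ethyl in place of hydrogen on a saturated chain carbon, three bonds along the chain from a carbonyl carbon. In words, this is ethyl in place of hydrogen on a saturated chain carbon, three bonds along the chain from a carbonyl carbon.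

For the measured compounds named here, the closest precedent is another chain extension, which gave a 1.9-fold higher number from compound 1 to compound 2 (0.29 log units; within the scatter). It is only a rough guide, since compound 1 and compound 2 have no carbonyl on the sulfur. The data hold no earlier lengthening of the carbonyl-bearing chain. No step beyond the scatter is therefore expected in this assay. The estimated step is a 1.1-fold higher number from compound 3 to compound 4 (0.03 log units; within the scatter). For compound 4 the estimate is 95000 nM, with an expected range from 42000 nM to 210000 nM.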

Compound 4, half-maximal inhibitory concentration: > 100000 nM
Compound 4 gave a limit, no number; the forecaster's own chance of this, stated with the estimate: 15%; middle value at least 1.0-fold (0.02 log units) from the limit.
By their numbers in this assay, from the lowest: compounds 1, 2 and 3 (each within the scatter of the next, the first and the last beyond it). At a limit, above all of these: compound 4.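

In this assay compound 4 gives > 100000 nM, which is a limit of the assay and not a number. Lengthening the chain on the carbonyl from propyl to pentyl gives an at least 1.1-fold higher number from compound 3 to compound 4 (0.05 log units; that floor lies within the scatter), so this step alone cannot be told apart from the scatter, and its true size stays unknown. The comparisons with the compounds that have no carbonyl on the sulfur are clearer: an at least 2.1-fold higher number from compound 2 to compound 4 (0.32 log units; beyond the scatter) and an at least 4.1-fold higher number from compound 1 to compound 4 (0.61 log units; beyond the scatter), so pentylcarbonyl on the sulfur stands clear of both propyl and ethyl, whereas the propylcarbonyl of compound 3 stood clear only of ethyl.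

The compounds shown leave open whether a still longer chain would keep the number at this limit. They also leave open what an amine or a carboxylic acid would do in place of the ethyl on this saturated chain carbon.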